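The source may hold more compounds than are shown below. What is called first, only, known or untested is meant among the compounds shown, and "the series" means these compounds.

Measured compounds:
compound 1 `O=C(CCCCCc1ccccc1)OCC1COCCOCCOCCOCCOCCO1`: 79000 nM
compound 2 `O=C(CCCCC1CCCCC1)OCC1COCCOCCOCCOCCO1`: > 100000 nM, a limit of the assay
compound 3 `O=C(CCCCC1CCCCC1)OCC1COCCOCCOCCO1`: > 100000 nM, a limit of the assay

Within the data shown here, in a functional assay on HeLa cells (Homo sapiens) for inhibition, read by sulforhodamine B assay, with a stated time of 48 h (on this read-out lower numbers stand for stronger inhibition of growth and higher numbers for weaker inhibition of growth), compound 1 gives 79000 nM, the only number reported among the three. For compound 2 the assay returns only a limit, > 100000 nM. For compound 3 the assay likewise returns only a limit, > 100000 nM. Among the measured compounds shown here, compound 1 therefore stands alone as a measured number, against (the limit of > 100000 nM in this assay, at which 2 of the 3 values shown sit), so there is no step between measured compounds to lean on.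

Compound 4 `O=C(OCC1COCCOCCOCCOCCOCCO1)c1cccnc1` differs from compound 1 in one place: pyridin-3-yl in place of 5-phenylpentyl on a carbonyl carbon. The crown-ether core is kept, and the ester carbonyl is retained.

For the measured compounds named here, with no measured step to guide the size, the expectation rests on compound 1 alone at 79000 nM, which already sits close to the top of what this assay reports. The step from compound 1 to compound 4 is expected to be small or toward weaker inhibition, a 1.3-fold higher number from compound 1 to compound 4 (0.10 log units; within the scatter), within or just beyond the scatter. Compound 4 is therefore estimated at 100000 nM, with a plausible range from 40000 nM to 300000 nM.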

Compound 4, concentration for 50% growth inhibition: > 100000 nM
Compound 4: no number, only a limit; the forecaster's own chance of this, stated with the estimate: 55%; the middle value sits exactly at the limit.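

Among these compounds, the exchange on this carbonyl carbon gives the first step that can be read, an at least 1.2-fold higher number from compound 1 to compound 4 (0.10 log units; that floor lies within the scatter), in this assay. The value of compound 4 is a limit and not a number, so this step is only a floor, and the true size of the change may lie within the scatter or well beyond it. With pyridin-3-yl in place of 5-phenylpentyl and the shared core and ester carbonyl kept, no stronger inhibition of growth appears, and compound 4 joins the compounds at the limit: the limit of > 100000 nM in this assay, at which 3 of the 4 values shown sit.

The compounds shown leave open whether the ring or the chain of 5-phenylpentyl matters more, since pyridin-3-yl changes both at once and no group here pairs a pyridin-3-yl ring with a pentyl chain. They also leave open whether an amine, a carboxylic acid or a longer chain at this place would move the number of compound 1 in either direction.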